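The compounds below may be only part of what the source reports. "The series", "measured", "known", "first", "only" and "open" are said of these compounds alone.

Three compounds share one core, and all three have been measured in a physicochemical assay for lipophilicity, at pH 7.4; a lower number here means a more polar compound, a higher number a more lipophilic compound. Compound 1, `CNC(=O)c1cc(C(=O)NCCC[C@H]2OC[C@H](N)CO2)cc2c1OC[C@H]2c1ccccc1`, gives 2.6 in this assay, the lowest of the three numbers. Compound 2, `CNC(=O)c1cc(C(N)=O)cc2c1OC[C@H]2c1ccccc1`, gives 2.7; the change a number 0.10 log units higher from compound 1 to compound 2 (within the scatter). Compound 3, `CCC(=O)N1C[C@@H]2[C@H](C1)[C@H]2NC(=O)c1cc(C(=O)NC)c2c(c1)[C@H](c1ccccc1)CO2`, gives 3.4; here the change a number 0.80 log units higher from compound 1 to compound 3 (beyond the scatter), and a number 0.70 log units higher from compound 2 to compound 3 (beyond the scatter). So compound 1 sits close to compound 2 and well beneath compound 3.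

The next compound, compound 4, is `CNC(=O)c1cc(C(=O)NCCC[C@H]2OC[C@H](N)CO2)cc2c1O[C@H](CF)[C@H]2c1ccccc1`. Compared with compound 1 it differs by fluoromethyl in place of hydrogen on a saturated ring carbon. For the measured compounds named here, this change sits on the core itself, on the saturated ring carbon next to the ring oxygen, whereas every measured step so far concerns the group on the amide-type nitrogen. None of those steps therefore bears directly on this change, and there is no shown step from which its size can be read off.

Adding two heavy atoms, one carbon and one fluorine, to a compound that already carries many is usually a small matter in this assay. The expected step is a number 0.30 log units higher from compound 1 to compound 4 (within the scatter), upward and about at the edge of the scatter. Compound 4 is therefore estimated to give 2.9 in this assay, with a range from 2.4 to 3.4.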

Compound 4, distribution coefficient: 2.9
Compound 4: middle estimate and measured number agree at the digits printed; low and high end bracket the measured number.
By their numbers in this assay, from the lowest: compounds 1, 2 and 4 (each within the scatter of the next); then compound 3.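

In this assay, fluoromethyl in place of hydrogen on a saturated ring carbon gives a number 0.30 log units higher from compound 1 to compound 4 (within the scatter), the first step shown that lies on the shared core and not on the group at the amide-type nitrogen. This saturated ring carbon, next to the ring oxygen and next to the ring atom that bears a phenyl group, can therefore take fluoromethyl without moving the number beyond what repeated measurements would scatter by, so compound 1 and compound 4 cannot be told apart in this read-out. Nothing available here explains the size of this step.

A single group at a single carbon says little about the position as a whole: a plain methyl, a hydroxymethyl or a trifluoromethyl on the same carbon, or fluoromethyl with the opposite spatial arrangement there, could each give a different step. It also remains open whether fluoromethyl would give a similar step with the other amide groups, for example on the core of compound 2 or compound 3, since the only pair shown for this change carries the side chain of compound 1.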